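The compounds below may be only part of what the source reports. "The series", "measured", "known", "first", "only" and "open" are said of these compounds alone.

Measured compounds:
compound 1 `CC(C)n1nc(-c2cccnc2)c2ccccc2c1=O`, 3090 nM; compound 2 `O=c1c2ccccc2c(-c2cccnc2)nn1CC1CCCCC1`, 209 nM; compound 3 `O=C(O)c1ccc(Cn2nc(-c3cccnc3)c3ccccc3c2=O)cc1`, 17000 nM.

In a functional assay (trachea) with Cavia porcellus as the target (on this read-out higher numbers stand for weaker inhibition and lower numbers for stronger inhibition), compound 1 gives 3090 nM, the second highest of the three numbers. Compound 2 reaches a lower number, a 15-fold lower number from compound 1 to compound 2 (1.17 log units; beyond the scatter), while compound 3 stands higher, at the top of the set.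

Compound 4 `NCCn1nc(-c2cccnc2)c2ccccc2c1=O` is not yet measured. It differs from compound 1 in one place: 2-aminoethyl in place of isopropyl on an aromatic nitrogen.

Going by the values given here, no measured step exchanges isopropyl for 2-aminoethyl, so the bearing steps are indirect. The step of a 15-fold lower number from compound 1 to compound 2 (1.17 log units; beyond the scatter) shows that a larger group without donors or acceptors on the aromatic nitrogen lowers the number strongly. The step of an 81-fold higher number from compound 2 to compound 3 (1.91 log units; beyond the scatter) shows that a group carrying a hydrogen-bond donor and acceptor on that side chain raises it strongly. The 2-aminoethyl group of compound 4 brings one donor and one acceptor and no ring, so a higher number than compound 1 is expected, though smaller than the step to compound 3, because the latter is an 81-fold higher number from compound 2 to compound 3 (1.91 log units; beyond the scatter) from a far lower starting point. Compound 4 is therefore expected to give 7000 nM, within 2000 nM to 25000 nM, corresponding to an estimated step of a 2.3-fold higher number from compound 1 to compound 4 (0.36 log units; beyond the scatter).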

Compound 4, half-maximal inhibitory concentration: > 100000 nM
Compound 4: no number, only a limit; the forecaster's own chance of this, stated with the estimate: 15%; at least 14-fold (1.15 log units) between middle value and limit.
By their numbers in this assay, from the lowest: compound 2; then compound 1; then compound 3. At a limit, above all of these: compound 4.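

In this assay compound 4 gives no number, only a limit: the limit of > 100000 nM in this assay, at which 1 of the 4 values shown sits.

Swapping isopropyl for 2-aminoethyl on the aromatic nitrogen keeps the count of 3 heavy atoms and adds no ring, yet it produces a large change, with an at least 32-fold higher number from compound 1 to compound 4 (1.51 log units; beyond the scatter), so the size of the group does not alone set the read-out at this position. The small 2-aminoethyl group also ends above the larger 4-carboxyphenyl-bearing side chain, with an at least 5.8-fold higher number from compound 3 to compound 4 (0.76 log units; beyond the scatter), and far above the cyclohexylmethyl group, with an at least 470-fold higher number from compound 2 to compound 4 (2.67 log units; beyond the scatter).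

The compounds shown leave open whether the amine itself or the chain carrying it accounts for this loss. A 2-hydroxyethyl group or a longer chain ending in an amine could separate these two readings.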